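The source may hold more compounds than are shown below. What is called first, only, known or untested is meant among the compounds shown, and "the series" means these compounds.

Compound 3, `CCOC(=O)N1CCC(N2CCC[C@@H](NC(=O)C3CCCC3)C2)CC1`, carries a cyclopentyl group on its amide carbonyl. In a functional assay on CHO cells for agonist activity at muscarinic acetylcholine receptor M5 (Rattus norvegicus) (on this read-out lower numbers stand for an effect already at smaller amounts and higher numbers for an effect only at larger amounts of compound), compound 3 gives > 10000 nM, which is a limit of the assay rather than a measured number. Compound 1, `CCOC(=O)N1CCC(N2CCC[C@@H](NC(=O)c3cccc(OC)c3)C2)CC1`, gives > 10000 nM in this assay, again only a limit. Compound 2, `CCOC(=O)N1CCC(N2CCC[C@@H](NC(=O)c3ccccc3Cl)C2)CC1`, gives > 10000 nM in this assay, also a limit. Because (the limit of > 10000 nM in this assay, at which 3 of the 3 values shown sit), none of the three steps between these compounds can be sized: a step that the two limits leave unreadable from compound 1 to compound 2, a step that the two limits leave unreadable from compound 1 to compound 3 and a step that the two limits leave unreadable from compound 2 to compound 3 all remain unreadable. Compound 4, `CCOC(=O)N1CCC(N2CCC[C@@H](NC(=O)c3cccc(F)c3)C2)CC1`, differs from compound 3 by 3-fluorophenyl in place of cyclopentyl on a carbonyl carbon. Within the data shown here, the steps that bear on this change, the exchanges of the group on the amide carbonyl among compounds 1, 2 and 3, all end at the same limit, so they give neither a direction nor a size. The expected step that the limit leaves unreadable from compound 3 to compound 4 is therefore no step beyond the scatter, with the result most likely once more reported as a limit. Compound 4 is estimated at 20000 nM, within a range from 5000 nM to 100000 nM.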

Compound 4, half-maximal effective concentration: > 10000 nM
Compound 4 ended at the assay's limit (the forecaster's own chance of this, stated with the estimate: 80%); the middle value lies beyond the limit too.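

Among these compounds, no step to compound 4 can be read from compound 1, compound 2 or compound 3, because each value is only a limit: the limit of > 10000 nM in this assay, at which 4 of the 4 values shown sit. The compounds shown leave open whether changing the group on the carbonyl alters the effect in this assay at all.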